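A Dimethylated Cyclohexanol in Place of a Methylene-Linked One

The source may hold more compounds than are shown below. What is called first, only, known or untested is meant among the compounds shown, and "the series" means these compounds.

The measured compounds:
compound 1, `N#Cc1cnc(NCc2ccccc2C(F)(F)F)cc1N[C@H]1CC[C@@H](O)CC1`, 4500 nM in an assay on isolated protein for inhibition of protein kinase C delta type (Homo sapiens), read by TR-FRET, with a stated time of 2 h; a higher number here means a weaker inhibitor, a lower number a stronger inhibitor
compound 2, `N#Cc1cnc(NCc2cnccc2C(F)(F)F)cc1NC[C@H]1CC[C@@H](O)CC1`, 500 nM in this assay
compound 3, `N#Cc1cnc(NCc2ccccc2)cc1N[C@H]1CC[C@@H](O)CC1`, > 10000 nM in this assay

Compound 3 reaches only a limit in this assay, not a number, as recorded in the limit of > 10000 nM in this assay, at which 1 of the 3 values shown sits. Among the two actual numbers, compound 2 has the lower one, and compound 1 gives the clearly higher 4500 nM. Compound 1 and compound 2 differ in more than one place, so only their two values can be compared. Within the data shown here, the single measured step, an at least 2.2-fold higher number from compound 1 to compound 3 (0.34 log units; beyond the scatter), is a change of trifluoromethyl to hydrogen on an aromatic carbon and does not touch the part changed here.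

Compound 4, `CC1(C)C[C@@H](Nc2cc(NCc3cnccc3C(F)(F)F)ncc2C#N)CC[C@@H]1O`, differs from compound 2 by 4-hydroxy-3,3-dimethylcyclohexyl in place of (4-hydroxycyclohexyl)methyl on a nitrogen on an aromatic ring. Among the measured compounds shown here, no measured step bears on this change, so no shift beyond the scatter is expected in this assay. Compound 4 is therefore estimated at 500 nM, between 150 nM and 1600 nM. That estimate means an expected step of no change at the digits printed from compound 2 to compound 4 (within the scatter), within the scatter.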

Compound 4, half-maximal inhibitory concentration: 2400 nM
For compound 4 the middle estimate is 4.8-fold (0.68 log units) below the measured one; the measured number lies above the stated range.
By their numbers in this assay, from the lowest: compound 2; then compounds 4 and 1 (each within the scatter of the next). At a limit, above all of these: compound 3.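

Replacing (4-hydroxycyclohexyl)methyl with 4-hydroxy-3,3-dimethylcyclohexyl on the nitrogen gives a 4.8-fold higher number from compound 2 to compound 4 (0.68 log units; beyond the scatter) in this assay, so the group at this place on the shared core affects the reading. Among these compounds, the earlier compounds could not show this, as their only single-place step concerned trifluoromethyl on an aromatic carbon. Nothing at hand explains the size of this step.

The swap makes two changes at once, removing the methylene link and adding the dimethyl substitution, and the compounds shown cannot say how much of the step belongs to each. Also open, on these data alone, is whether a ring carrying an amine or a carboxylic acid in place of the hydroxy group would read differently in this assay at this same place.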